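The source may report more compounds than this note shows. Statements on the series, on what has been measured and on what is new or still open speak of the compounds shown alone.

Compound 1 `Nc1nnc(SC[C@H]2O[C@@H](OCc3noc(-c4ccc(Cl)cc4)n3)[C@@H]3OC4(CCCC4)O[C@@H]32)s1`: 15000 nM
Compound 2 `O=[N+]([O-])c1ccc(-c2nc(CO[C@@H]3O[C@H](CSc4ncn[nH]4)[C@H]4OC5(CCCC5)O[C@@H]34)no2)cc1`: 20000 nM

In a functional assay on WiDr cells (Homo sapiens) for antiproliferative activity, read by sulforhodamine B assay, with a stated time of 48 h (a higher number here means a weaker inhibitor of growth, a lower number a stronger inhibitor of growth), compound 2 gives 20000 nM, the higher of the two numbers; the nearest, compound 1, gives 15000 nM, and the gap between them lies within the scatter, so the two values show no order. Compound 3 `Clc1ccc(-c2nc(CO[C@@H]3O[C@H](CSc4ncn[nH]4)[C@H]4OC5(CCCC5)O[C@@H]34)no2)cc1` differs from compound 2 by chloro in place of nitro on an aromatic carbon. Going by the values given here, no measured pair in this set isolates that change. Among the compounds with values here, compound 1 does carry the 4-chlorophenyl group, but it differs from compound 2 in a second place as well, so the two values say only that a chlorophenyl compound and a nitrophenyl compound land close together in this assay. On that basis the author expects the change from nitro to chloro to produce no step beyond the scatter. Compound 3 is therefore estimated to give about 17000 nM, with a range from 6000 nM to 50000 nM. That estimate means a step of a 1.2-fold lower number from compound 2 to compound 3 (0.07 log units; within the scatter), expected to stay inside the usual scatter.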

Compound 3, concentration for 50% growth inhibition: 4500 nM
Compound 3: middle estimate off by 3.8-fold (0.58 log units), on the high side; the whole stated range lies above it.
By their numbers in this assay, from the lowest: compound 3; then compounds 1 and 2 (each within the scatter of the next).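

Replacing 4-nitrophenyl with 4-chlorophenyl on the shared core matters at this aromatic carbon: in this assay the change gives a 4.4-fold lower number from compound 2 to compound 3 (0.65 log units; beyond the scatter), a step that compares a single difference, which the earlier values could not do, as the two compounds then in hand differed in two places and showed no order. The 4-chlorophenyl group alone does not set the value either, for with that group held constant, 1H-1,2,4-triazol-5-yl in place of 5-amino-1,3,4-thiadiazol-2-yl on the sulfur gives a 3.3-fold lower number from compound 1 to compound 3 (0.52 log units; beyond the scatter), so the lower number appears only with the chloro and triazole groups together among these compounds. Nothing available here accounts for either step.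

The compounds shown leave open whether the nitro-to-chloro step would keep its size with the 5-amino-1,3,4-thiadiazol-2-yl group on the sulfur, as the two changes have not been seen apart on that background. They also leave open how other groups at the same aromatic carbon, such as fluoro, methoxy or an amine, would stand against chloro.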